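Same Substitution, Second Core: Predicting Compound 4

The compounds below may be only part of what the source reports. "The series", "measured", "known", "first", "only" and "open" are said of these compounds alone.

The study compares two pairs of compounds that share one structural change. Compound 1 `COc1ccc(OC)c(/C=C/C(=O)C(=Cc2ccc(O)c(OC)c2)C(=O)/C=C/c2cc(OC)ccc2OC)c1` and compound 2 `COc1ccc(OC)c(/C=C/C(=O)C(=Cc2ccc(O)c(F)c2)C(=O)/C=C/c2cc(OC)ccc2OC)c1` belong to the first core; compound 3 `COc1cc(OC)c(/C=C/C(=O)C(=Cc2ccc(O)c(OC)c2)C(=O)/C=C/c2c(OC)cc(OC)cc2OC)c(OC)c1` and compound 4 `COc1cc(OC)c(/C=C/C(=O)C(=Cc2ccc(O)c(F)c2)C(=O)/C=C/c2c(OC)cc(OC)cc2OC)c(OC)c1` belong to the second. The difference between the two cores is not broken down here.

In a functional assay on A549 cells (Homo sapiens) for antiproliferative activity, read by sulforhodamine B assay, with a stated time of 48 h (a lower number here means a stronger inhibitor, a higher number a weaker inhibitor), compound 1 gives 190 nM. Compound 2 gives 220 nM in this assay. The change between them is fluoro in place of methoxy on an aromatic carbon and it produced a 1.2-fold higher number from compound 1 to compound 2 (0.06 log units; within the scatter). Compound 3 gives 580 nM in this assay, the highest of the three measured numbers, standing beyond the scatter from both compound 1 and compound 2.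

Compound 4 carries the same change on the second core: fluoro in place of methoxy on an aromatic carbon. The place of the change reads the same in both pairs, so it is the same change, made twice among the compounds shown. Because the earlier step was a 1.2-fold higher number from compound 1 to compound 2 (0.06 log units; within the scatter), the step from compound 3 to compound 4 is expected to be small as well, estimated as a 1.2-fold higher number from compound 3 to compound 4 (0.07 log units; within the scatter). Compound 4 is therefore expected to give about 680 nM in this assay, with the estimate spanning from 350 nM to 1400 nM. This rests on a single precedent pair, so the range is kept wide.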

Compound 4, half-maximal inhibitory concentration: 1060 nM
Beside the measured number, compound 4's estimate is 1.6-fold (0.19 log units) below it, and the stated range covers the measured number.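

In this assay, the swap from the 4-hydroxy-3-methoxyphenyl group to the 3-fluoro-4-hydroxyphenyl group on the second core reads as a 1.8-fold higher number from compound 3 to compound 4 (0.26 log units; within the scatter), so on this core too the step does not stand out from the usual spread of repeated measurements. Set beside the step on the first core, the new step does not differ from it, and in this series the change carries from one core to the other without a detectable difference: the same change on two cores in this assay, a 1.2-fold higher number (0.06 log units; within the scatter) from compound 1 to compound 2 and a 1.8-fold higher number (0.26 log units; within the scatter) from compound 3 to compound 4, 1.6-fold (0.20 log units) apart, within the scatter of two such steps. Within the data shown here, this shows agreement between only two pairs, in one cell line and one read-out; since both steps lie within the scatter, it neither proves that fluoro and methoxy are interchangeable at this place nor establishes a rule for any core beyond these.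

The compounds shown leave open whether other groups at this place, such as chloro, ethoxy, an amine or a carboxylic acid, would also give matching steps on both cores. They also leave open how the same change would read on a third core, or whether the hydroxy group it sits ortho to has any part in the result.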